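The compounds below may be only part of what the source reports. "The series", "measured", "known", "first", "only" and "open" are said of these compounds alone.

Among the measured compounds shown here, compound 1 `Cc1nn(-c2nc(-c3ccc(Cl)c(Cl)c3)c(SC(C)C)s2)c(C(=O)O)c1-c1cccc(Cl)c1C` is the only compound in this set that comes with a number: in a functional assay on BJAB cells (Homo sapiens) for antiproliferative activity, with a stated time of 4 days (a higher number here means that more compound is needed for the effect, a lower number that less compound is needed), compound 1 gives 5100 nM. Compound 2 `Cc1c(-c2cc(Cl)cc(Cl)c2)c(C(=O)O)nn1-c1nc(-c2ccc3nccn3c2)c(SC(C)C)s1` carries a different pair of aromatic groups, and in this assay compound 2 gives "not active" (no number reported), so compound 1 stands alone among the measured compounds as the one with a measurable result. Compound 3 `CC(=O)Nc1ccc(-c2c(C)nn(-c3nc(-c4ccc(Cl)c(Cl)c4)c(SC(C)C)s3)c2C(=O)O)cc1` has not yet been tested. It differs from compound 1 in one place: 4-acetamidophenyl in place of 3-chloro-2-methylphenyl on an aromatic carbon. For the measured compounds named here, no pair of measured compounds differs in only one place, so there is no measured step to lean on for a change of this kind. Compound 1 already needs a high concentration in this assay, as its value 5100 nM shows, and the expected step of a 1.6-fold higher number from compound 1 to compound 3 (0.20 log units; within the scatter) is a small loss, at or only a little beyond the scatter. Compound 3 is therefore expected to give about 8000 nM in this assay, within a range from 2500 nM to 25000 nM, with a real chance that only a limit is reported.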

Compound 3, half-maximal effective concentration: 139000 nM
Estimate against measurement, compound 3: 17-fold (1.24 log units) below; the whole stated range lies below it.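

The swap on this aromatic carbon, where 3-chloro-2-methylphenyl gives way to 4-acetamidophenyl, produces a large change in this assay, with a 27-fold higher number from compound 1 to compound 3 (1.44 log units; beyond the scatter). Among the compounds shown here, until now no measured pair differed in only one place, so this is the first direct sign that the group at this position, next to the ring atom that bears a carboxy group and next to the ring atom that bears a methyl group, strongly affects how much compound is needed for the effect. Nothing measured on these compounds explains why the step is so large.

As far as these compounds go, this single step changes several things together: the chlorine and the methyl leave, while an amide with its hydrogen-bond donor and acceptor enters, and the substitution pattern on the phenyl ring shifts, so the contribution of each remains open. Also unresolved is how this assay would respond at this carbon to a plain phenyl, to a 4-aminophenyl or to a 3-acetamidophenyl, the last of which would carry the same amide at a different point on the phenyl ring.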